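The compounds below may be only part of what the source reports. "The series", "measured", "known", "first", "only" and "open" are said of these compounds alone.

Three compounds share one core, differing only in the group on the carbon with a double bond to nitrogen. Compound 1 `O=C(CSc1nnc(-c2ccncc2)o1)N/N=C/c1ccc(Cl)cc1` carries a 4-chlorophenyl there, and in a functional assay on BGC-823 cells (Homo sapiens) for cytotoxicity, read by MTT assay, with a stated time of 48 h (on this read-out higher numbers stand for weaker inhibition and lower numbers for stronger inhibition), compound 1 gives 20500 nM. Compound 2 `O=C(CSc1nnc(-c2ccncc2)o1)N/N=C/c1ccc(Br)cc1` has bromo in place of chloro on an aromatic carbon; in this assay compound 2 gives 24500 nM, and the step is a 1.2-fold higher number from compound 1 to compound 2 (0.08 log units; within the scatter). Compound 3 `O=C(CSc1nnc(-c2ccncc2)o1)N/N=C/c1cc(Cl)cc(Cl)c1O` carries a 3,5-dichloro-2-hydroxyphenyl instead, and in this assay compound 3 gives 6340 nM; the steps to it are a 3.2-fold lower number from compound 1 to compound 3 (0.51 log units; beyond the scatter) and a 3.9-fold lower number from compound 2 to compound 3 (0.59 log units; beyond the scatter). Among these three, compound 2 has the highest number, although its gap to compound 1 lies within the scatter and only compound 3 sits clearly apart.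

Compound 4 `O=C(CSc1nnc(-c2ccncc2)o1)N/N=C/c1ccc(Cl)cc1Cl` is not yet measured. Relative to compound 2 the change is 2,4-dichlorophenyl in place of 4-bromophenyl on a carbon with a double bond to nitrogen. For the measured compounds named here, two measured steps bear on it: the halogen exchange a 1.2-fold higher number from compound 1 to compound 2 (0.08 log units; within the scatter) was flat, while the move to compound 3 a 3.9-fold lower number from compound 2 to compound 3 (0.59 log units; beyond the scatter) lowered the number modestly, though that move also brought in a hydroxyl that compound 4 lacks. In this assay the expected step is therefore a 1.6-fold lower number from compound 2 to compound 4 (0.21 log units; within the scatter), a small lowering at most. Compound 4 is estimated at 15000 nM, within a range of 6000 nM to 35000 nM.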

Compound 4, half-maximal inhibitory concentration: 35600 nM
The estimate for compound 4 lay 2.4-fold (0.38 log units) below the measured number; measured number above the stated range.
By their numbers in this assay, from the lowest: compound 3; then compounds 1, 2 and 4 (each within the scatter of the next).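

In this assay adding a chloro to the 4-chlorophenyl gives a 1.7-fold higher number from compound 1 to compound 4 (0.24 log units; within the scatter) and replacing 4-bromophenyl with 2,4-dichlorophenyl gives a 1.5-fold higher number from compound 2 to compound 4 (0.16 log units; within the scatter), so on this carbon with a double bond to nitrogen, a second chloro on the ring does not by itself produce the separation seen with compound 3. The step from the 3,5-dichloro-2-hydroxyphenyl to the 2,4-dichlorophenyl is the largest so far and lies beyond the scatter, as a 5.6-fold higher number from compound 3 to compound 4 (0.75 log units; beyond the scatter) shows, but these groups differ in both the hydroxyl and where the chloro groups sit, so this step cannot be assigned to either difference alone. No measured evidence is available to explain these results.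

On these data alone, whether a 2-hydroxyphenyl or a 3,5-dichlorophenyl on this carbon would keep the lower number remains open, and either would help to separate the contribution of the hydroxyl from that of the chloro groups. Also open, as far as these compounds go, is what a methoxy or an amino group in place of the hydroxyl on the 3,5-dichlorophenyl ring would do.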